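Benzylsulfanyl enone series: fluoro to methyl on the benzyl ring

The source may hold more compounds than are shown below. What is called first, only, known or untested is meant among the compounds shown, and "the series" means these compounds.

Measured so far in a functional assay on DU-145 cells (Homo sapiens) for inhibition, read by trypan blue exclusion, with a stated time of 96 h; a lower number here means a stronger inhibitor of growth, a higher number a weaker inhibitor of growth:
- compound 1 `O=C(/C(=C\c1ccccc1OCc1ccccc1)SCc1ccc(F)cc1)c1ccc(Cl)cc1`: 1000 nM
- compound 2 `COc1ccccc1/C=C(/SCc1ccc(F)cc1)C(=O)c1ccc(Cl)cc1`: 10000 nM
- compound 3 `O=C(/C(=C\c1ccccc1OCc1ccccc1)SCc1ccc(F)cc1)c1ccc(Br)cc1`: 1000 nM

Compound 1 and compound 3 stand level at the digits printed, together the lowest two numbers of the three; compound 2 is the furthest from compound 1, a 10-fold higher number from compound 1 to compound 2 (1.00 log units; beyond the scatter). The halogen swap on the ketone-bearing ring gave no change at the digits printed from compound 1 to compound 3 (within the scatter).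

Compound 4 `Cc1ccc(CS/C(=C/c2ccccc2OCc2ccccc2)C(=O)c2ccc(Cl)cc2)cc1` is not yet measured. It differs from compound 1 as follows: methyl in place of fluoro on an aromatic carbon.

Among the measured compounds shown here, neither measured step touches the benzylsulfanyl ring, so no step bears directly on this change. For the measured compounds named here, the only substituent swap on an aromatic carbon, from compound 1 to compound 3, left the number unchanged within the scatter, while the large step from compound 1 to compound 2 came from removing phenyl at a different site. A small substituent exchange on a ring that has not been varied so far is therefore expected to give no step beyond the scatter, no change at the digits printed from compound 1 to compound 4 (within the scatter). Compound 4 is estimated at 1000 nM, with a range of 400 nM to 2500 nM.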

Compound 4, concentration for 50% growth inhibition: 1000 nM
Compound 4: middle estimate and measured number agree at the digits printed, within the range that was stated.
By their numbers in this assay, from the lowest: compounds 1, 3 and 4 (each within the scatter of the next); then compound 2.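

Among the compounds shown here, the step in this assay is the first reading on the benzyl ring, and 4-fluorobenzyl to 4-methylbenzyl gives no change at the digits printed from compound 1 to compound 4 (within the scatter) at this position. Fluoro is therefore not required to hold the number of compound 1, and methyl serves equally well on this aromatic carbon. Nothing on hand explains why the two groups read alike.

From the compounds shown here alone, only fluoro and methyl have been read here, so it remains open how an amine, a carboxylic acid or a longer alkyl chain at this position would read. Also open, going by these compounds, is whether the same exchange would leave the number unchanged on compound 2, where the step away from compound 1 lies beyond the scatter.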